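Thiomethyl variation on a shared core: from propenyl to cyclohexylmethyl

The source may report more compounds than this note shows. Statements on the series, on what has been measured and on what is new or still open speak of the compounds shown alone.

Measured compounds:
compound 1, `C#CCSc1nc(Nc2cccc(OC)c2)c2ccncc2n1`, 920 nM
compound 2, `C/C=C/Sc1nc(Nc2cccc(OC)c2)c2ccncc2n1`, 18100 nM

Within the data shown here, in a functional assay on HepG2 cells (Homo sapiens) for inhibition, read by MTT assay, with a stated time of 72 h (on this read-out higher numbers stand for weaker inhibition and lower numbers for stronger inhibition), compound 2 gives 18100 nM, the highest of the two numbers known here. Among the measured compounds shown here, compound 1 sits on the nearest number to it, at 920 nM, and the only measured step, a 20-fold higher number from compound 1 to compound 2 (1.29 log units; beyond the scatter), shows that a change of the group on the sulfur can move the read-out a long way. Compound 3, `COc1cccc(Nc2nc(SCC3CCCCC3)nc3cnccc23)c1`, differs from compound 2 by cyclohexylmethyl in place of prop-1-en-1-yl on a sulfur. For the measured compounds named here, no measured step covers this exact exchange; the one step at the same sulfur, from compound 1 to compound 2, is the sole guide and it went up. Going by the values given here, a saturated ring-bearing group has no precedent in this set, so the direction is uncertain, though a return toward the number of compound 1 is plausible. The step from compound 2 to compound 3 in this assay is therefore expected to be a 3.0-fold lower number from compound 2 to compound 3 (0.48 log units; beyond the scatter), and compound 3 is estimated at 6000 nM, with a range of 1200 nM to 30000 nM.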

Compound 3, half-maximal inhibitory concentration: 32800 nM
The estimate for compound 3 lay 5.5-fold (0.74 log units) below the measured number; the measured number lies above the stated range.
By their numbers in this assay, from the lowest: compound 1; then compounds 2 and 3 (each within the scatter of the next).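

In this assay, the exchange of prop-1-en-1-yl for cyclohexylmethyl on the sulfur gives a 1.8-fold higher number from compound 2 to compound 3 (0.26 log units; within the scatter), so these two quite different groups cannot be told apart on this read-out, and the ring brings no return toward compound 1. The comparison with the propargyl compound, a 36-fold higher number from compound 1 to compound 3 (1.55 log units; beyond the scatter), shows that the earlier gap was not particular to prop-1-en-1-yl: among these three compounds, only compound 1 stands apart from the others. No supporting data bear on why the numbers fall this way.

The compounds shown leave open whether the terminal ethynyl of the propargyl group is what sets compound 1 apart, which a but-2-yn-1-yl group or an allyl group on the sulfur could test. They also leave open how a plain methyl or a benzyl group would read at this position.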